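The source may report more compounds than this note shows. Statements on the series, on what has been measured and on what is new or still open speak of the compounds shown alone.

The measured compounds are:
compound 1, `CCC[C@H](CCn1cncn1)c1ccc(F)cc1`, which gives 39.3 ug/mL;
compound 2, `CCC[C@H](CCn1cncn1)c1ccc(C)cc1`, which gives 45.7 ug/mL;
compound 3, `CCCC[C@H](CCn1cncn1)c1ccc(F)cc1`, which gives 38.5 ug/mL.

All three numbers come from an ADME assay on HEp-2 cells (Homo sapiens) for cytotoxicity, read by MTT assay, with a stated time of 3 days; on this read-out higher numbers stand for lower toxicity in this test and lower numbers for higher toxicity in this test. Compound 4, `CCCC[C@H](CCn1cncn1)c1ccc(C)cc1`, has not yet been tested in this assay. It is made from compound 3 by one change, (methyl in place of fluoro on an aromatic carbon). The same change has already been measured once, going from compound 1 to compound 2, where it made a 1.2-fold higher number from compound 1 to compound 2 (0.07 log units; within the scatter). The two starting points differ in their cores: compound 3 differs from compound 1 by methyl in place of hydrogen on a saturated chain carbon, four bonds along the chain from an aromatic carbon, and that difference on its own made a 1.0-fold lower number from compound 1 to compound 3 (0.01 log units; within the scatter). The place of the change is described in the same words for both pairs, so it is the same change, now made on the core of compound 3. Because the earlier step was a 1.2-fold higher number from compound 1 to compound 2 (0.07 log units; within the scatter), compound 4 is expected to show a step of similar small size, a 1.2-fold higher number from compound 3 to compound 4 (0.07 log units; within the scatter). Compound 4 is therefore estimated at 45 ug/mL, most likely between 25 ug/mL and 80 ug/mL. This rests on two measured pairs only, so the range is kept wide.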

Compound 4, half-maximal cytotoxic concentration: 23.7 ug/mL
For compound 4 the middle estimate is 1.9-fold (0.28 log units) above the measured one; measured number below the stated range.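

In this assay, methyl in place of fluoro on the core of compound 3 gives a 1.6-fold lower number from compound 3 to compound 4 (0.21 log units; within the scatter), and this step cannot be told apart from the one seen earlier on the other core: the same change on two cores in this assay, a 1.2-fold higher number (0.07 log units; within the scatter) from compound 1 to compound 2 and a 1.6-fold lower number (0.21 log units; within the scatter) from compound 3 to compound 4, 1.9-fold (0.28 log units) apart, within the scatter of two such steps. Methyl in place of hydrogen on the saturated chain gives a 1.9-fold lower number from compound 2 to compound 4 (0.29 log units; within the scatter), and this step also cannot be told apart from its earlier counterpart: the same change on two cores in this assay, a 1.0-fold lower number (0.01 log units; within the scatter) from compound 1 to compound 3 and a 1.9-fold lower number (0.29 log units; within the scatter) from compound 2 to compound 4, 1.9-fold (0.28 log units) apart, within the scatter of two such steps. So neither change is shown to behave differently from one core to the other, but with only two pairs for each change and every step within the scatter, this does not prove that the steps carry over unchanged.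

The compounds shown leave open whether a chloro, methoxy or nitrile group in the same place on the aromatic ring would give a step beyond the scatter. They also leave open what a longer chain would do on either core.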